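The compounds below may be only part of what the source reports. "The series", "measured", "known", "first", "only" and "open" are said of these compounds alone.

Measured so far: compound 1 `COc1ccc(CNCc2c(-c3nnc(SC(C)C)n3-c3ccccc3)n(C)c3ccc(F)cc23)cc1` gives 6.42 in a physicochemical assay for lipophilicity; on this read-out higher numbers stand for higher lipophilicity and lower numbers for lower lipophilicity; compound 2 `CC(C)Sc1nnc(-c2c(CNCC3CC3)c3ccccc3n2C)n1-c1ccccc1` gives 5.24; compound 3 `COCCNCc1c(-c2nnc(SC(C)C)n2-c2ccccc2)n(C)c2ccc(F)cc12` gives 4.52.

Compound 2 stands second highest of these three: its value lies beyond the scatter below that of compound 1 and beyond the scatter above that of compound 3. Compound 4 `COc1cccc(CNCc2c(-c3nnc(SC(C)C)n3-c3ccccc3)n(C)c3ccccc23)c1` is not yet measured. It differs from compound 2 by 3-methoxyphenyl in place of cyclopropyl on a saturated chain carbon bound to an amine nitrogen. Among the compounds with values here, only one measured step bears on this kind of change: the step of a number 1.90 log units lower from compound 1 to compound 3 (beyond the scatter), where a methoxyphenyl group was traded for a much smaller chain. Reversing that sense, swapping a small cyclopropyl for a 3-methoxyphenyl is expected to raise the number by a large step, a number 0.96 log units higher from compound 2 to compound 4 (beyond the scatter). Compound 4 is therefore estimated at 6.2, within a range from 5.7 to 6.7.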

Compound 4, partition coefficient: 6.27
Estimate against measurement, compound 4: 0.07 log units below, and the stated range covers the measured number.
By their numbers in this assay, from the lowest: compound 3; then compound 2; then compounds 4 and 1 (each within the scatter of the next).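

In this assay, trading the cyclopropyl group for the 3-methoxyphenyl group gives a number 1.03 log units higher from compound 2 to compound 4 (beyond the scatter). A large step at this position therefore does not belong only to the earlier pair of groups: it appears again with a different aromatic group and a different small group, on a core without the fluorine of compound 1 and compound 3. Nothing shown here accounts for the size of this step. Still open, going by these compounds, is how much of the step follows the aromatic ring and how much its methoxy group, and what a plain phenyl or a carboxylic acid on that ring would give.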